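The compounds below may be only part of what the source reports. "The series", "measured", "known", "first", "only" and "open" are said of these compounds alone.

Three compounds have so far been measured in a functional assay on MCF7 cells (Homo sapiens) for inhibition, read by MTT assay, with a stated time of 2 days; a higher number here means a weaker inhibitor, a lower number a stronger inhibitor:

compound 1 `Oc1ccccc1/C=C/c1ccccc1O`, 23 ug/mL
compound 2 `Oc1ccc(/C=C/c2ccccc2O)cc1`, 21 ug/mL
compound 3 `COc1ccccc1/C=C/c1ccccc1O`, 17.9 ug/mL

Compound 3 differs from compound 1 by one change, (methyl in place of hydrogen on an oxygen on an aromatic ring), and in this assay that change gave a 1.3-fold lower number from compound 1 to compound 3 (0.11 log units; within the scatter). Compound 2 is built from the same atoms as compound 1, joined differently; the difference between the two cores is not broken down here, and the two values lie within the scatter of each other.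

Compound 4 `COc1ccc(/C=C/c2ccccc2O)cc1` has not yet been measured. It differs from compound 2 by methyl in place of hydrogen on an oxygen on an aromatic ring, the same change, at the same kind of place, as that from compound 1 to compound 3. Because that earlier change gave a 1.3-fold lower number from compound 1 to compound 3 (0.11 log units; within the scatter), the step from compound 2 to compound 4 in this assay is expected to be a 1.2-fold lower number from compound 2 to compound 4 (0.09 log units; within the scatter), a shift well inside the scatter. On this basis compound 4 is estimated at 17 ug/mL, most likely between 9 ug/mL and 32 ug/mL.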

Compound 4, half-maximal inhibitory concentration: 17 ug/mL
Compound 4: middle estimate and measured number agree at the digits printed; the measured number falls inside the stated range.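

In this assay, the change from hydroxy to methoxy gave a 1.2-fold lower number from compound 2 to compound 4 (0.09 log units; within the scatter). Set beside the earlier step, the change reads alike on the two cores: the same change on two cores in this assay, a 1.3-fold lower number (0.11 log units; within the scatter) from compound 1 to compound 3 and a 1.2-fold lower number (0.09 log units; within the scatter) from compound 2 to compound 4, 1.0-fold (0.02 log units) apart, within the scatter of two such steps. For the compounds shown here, since both steps lie within the scatter, this shows only that the change left the result within the scatter on each of these two cores; it does not show that a real effect carries from one core to the other, nor that the same would hold on any further core.

The compounds shown leave open what a longer chain on that oxygen would give. They also leave open what an amine or a carboxylic acid in that place would give.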